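Furan to pyrrole on an adenosine receptor agonist series

The compounds below may be only part of what the source reports. "The series", "measured", "known", "first", "only" and "open" are said of these compounds alone.

Measured compounds: compound 1 `CCNC(=O)[C@H]1O[C@@H](n2cnc3c(NNC(=O)c4ccc(Br)o4)ncnc32)[C@H](O)[C@@H]1O` gives 369 nM; compound 2 `CCNC(=O)[C@H]1O[C@@H](n2cnc3c(NNC(=O)c4ccc(C)o4)ncnc32)[C@H](O)[C@@H]1O` gives 227 nM; compound 3 `CCNC(=O)[C@H]1O[C@@H](n2cnc3c(NNC(=O)c4ccco4)nc(Cl)nc32)[C@H](O)[C@@H]1O` gives 210 nM in a functional assay on CHO cells for activation of adenosine receptor A2b (Homo sapiens), read by cAMP accumulation; on this read-out lower numbers stand for an effect already at smaller amounts and higher numbers for an effect only at larger amounts of compound.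

Compound 3 stands at one end of the three numbers, but its gaps to compound 2 and to compound 1 are both within the scatter. Compound 4 `CCNC(=O)[C@H]1O[C@@H](n2cnc3c(NNC(=O)c4ccc[nH]4)nc(Cl)nc32)[C@H](O)[C@@H]1O` differs from it by 1H-pyrrol-2-yl in place of furan-2-yl on a carbonyl carbon. Going by the values given here, the only measured step, a 1.6-fold lower number from compound 1 to compound 2 (0.21 log units; within the scatter), changes a substituent on the furan ring rather than the ring itself, so no measured step directly bears on this exchange. The step from compound 3 to compound 4 is therefore expected to be no change at the digits printed from compound 3 to compound 4 (within the scatter), with no change beyond the scatter. Compound 4 is estimated at 210 nM, with a range from 70 nM to 630 nM.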

Compound 4, half-maximal effective concentration: 359 nM
For compound 4 the middle estimate is 1.7-fold (0.23 log units) below the measured one; the measured number falls inside the stated range.
By their numbers in this assay, from the lowest: compounds 3, 2, 4 and 1 (each within the scatter of the next).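

In this assay, placing 1H-pyrrol-2-yl in place of furan-2-yl on a carbonyl carbon gives a 1.7-fold higher number from compound 3 to compound 4 (0.23 log units; within the scatter). Earlier compounds varied only a substituent on the furan ring, whereas this step shows that the ring itself can be exchanged, with a hydrogen-bond acceptor leaving and a hydrogen-bond donor entering, without a change beyond the scatter. Nothing available gives a cause for the size of this step. Still open, as far as these compounds go, is whether thiophen-2-yl or phenyl on that carbonyl carbon would stay within the scatter. Also open, from the compounds shown here alone, is whether bromo or methyl on the 1H-pyrrol-2-yl ring would read as they do on the furan ring.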